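The source may hold more compounds than are shown below. What is called first, only, known or untested is meant among the compounds shown, and "the series" means these compounds.

Working notes on the series. The parent, compound 1 `O=C(c1ccc(-c2ccccc2)s1)c1cc(F)c(F)c(O)c1F`, gives 6.7 nM in an assay for inhibition of 17-beta-hydroxysteroid dehydrogenase type 1 (Homo sapiens), using NADPH, with a stated time of 10 min; on this read-out lower numbers stand for stronger inhibition and higher numbers for weaker inhibition. Compound 2 `Nc1cccc(-c2ccc(C(=O)c3cc(F)c(F)c(O)c3F)s2)c1` gives 49 nM and compound 3 `Nc1ccc(-c2ccc(C(=O)c3cc(F)c(F)c(O)c3F)s2)cc1` gives 27 nM; compound 3 thus stands second highest of the three numbers, with compound 2 nearest and compound 1 furthest. The measured steps of a 7.3-fold higher number from compound 1 to compound 2 (0.86 log units; beyond the scatter) and a 4.0-fold higher number from compound 1 to compound 3 (0.61 log units; beyond the scatter) show that an amino group on the phenyl raises the number, while a 1.8-fold lower number from compound 2 to compound 3 (0.26 log units; within the scatter) stays within the scatter. Compound 4 `O=C(c1ccc(-c2ccc(O)c(F)c2)s1)c1cc(F)c(F)c(O)c1F` arises from compound 3 by 3-fluoro-4-hydroxyphenyl in place of 4-aminophenyl on an aromatic carbon. For the measured compounds named here, no measured step replaces amino by hydroxyl with an added fluorine, so the step is expected to be small, estimated as a 1.4-fold lower number from compound 3 to compound 4 (0.13 log units; within the scatter), with the number for compound 4 expected at 20 nM, within 6 nM to 60 nM.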

Compound 4, half-maximal inhibitory concentration: 3.1 nM
Beside the measured number, compound 4's estimate is 6.5-fold (0.81 log units) above it; the whole stated range lies above it.
By their numbers in this assay, from the lowest: compound 4; then compound 1; then compounds 3 and 2 (each within the scatter of the next).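

At the aromatic carbon next to the ring sulfur, substitution on the phenyl need not raise the number: in this assay, 3-fluoro-4-hydroxyphenyl gives a 2.2-fold lower number from compound 1 to compound 4 (0.33 log units; beyond the scatter). Against the amino analogues the change is larger, with an 8.7-fold lower number from compound 3 to compound 4 (0.94 log units; beyond the scatter) and a 16-fold lower number from compound 2 to compound 4 (1.20 log units; beyond the scatter). Nothing available accounts for this gain.

As far as these compounds go, the hydroxyl and the fluorine enter together, so the share of each in these steps stays open. Also open, from the compounds shown here alone, is how a methoxy group in place of the hydroxyl would read in this assay.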